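Methylsulfanyl in Place of Bromo on the Shared Core

The source may hold more compounds than are shown below. What is called first, only, known or untested is meant among the compounds shown, and "the series" means these compounds.

Compound 1 `OCCCCCC(O)c1ccc(-c2ccc(Br)cc2)cc1` carries a bromo group on one aromatic ring of its core. Among the compounds with values here, in a functional assay on J774 cells (Mus musculus) for cytotoxicity, read by resazurin assay (a higher number here means a weaker inhibitor, a lower number a stronger inhibitor), compound 1 gives 20000 nM, the lowest of the three numbers measured so far, although the other two sit very close to it: compound 2 `OCCCCCC(O)c1ccc(-c2ccccc2F)cc1` gives 22000 nM and compound 3 `Cc1ccccc1-c1ccc(C(O)CCCCCO)cc1` gives 24000 nM. The step of a 1.1-fold higher number from compound 1 to compound 2 (0.04 log units; within the scatter) and the step of a 1.2-fold higher number from compound 1 to compound 3 (0.08 log units; within the scatter) both fall within the scatter, and so does a 1.1-fold higher number from compound 2 to compound 3 (0.04 log units; within the scatter). In other words, the three compounds cannot be told apart on these numbers.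

Compound 4 `CSc1ccc(-c2ccc(C(O)CCCCCO)cc2)cc1` differs from compound 1 in a single place: methylsulfanyl in place of bromo on an aromatic carbon. Within the data shown here, no measured step involves a methylsulfanyl group, so there is no direct guide. What the data do show is that exchanging one small group for another on that ring has so far left the readout unchanged, as a 1.1-fold higher number from compound 1 to compound 2 (0.04 log units; within the scatter) and a 1.2-fold higher number from compound 1 to compound 3 (0.08 log units; within the scatter) demonstrate. The expected step of a 1.1-fold higher number from compound 1 to compound 4 (0.04 log units; within the scatter) is therefore estimated to stay within the scatter, with no clear direction.

Compound 4 is expected to give about 22000 nM, with a likely range from 10000 nM to 48000 nM.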

Compound 4, half-maximal inhibitory concentration: 24000 nM
Estimate against measurement, compound 4: 1.1-fold (0.04 log units) below, and the stated range covers the measured number.
By their numbers in this assay, from the lowest: compounds 1, 2, 3 and 4 (each within the scatter of the next).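

Within the data shown here, compounds 2 and 3 exchanged the whole 4-bromophenyl group, whereas compound 4 keeps that ring and alters only the group on the aromatic carbon para to a large group, so this is the first direct look at that position. There, methylsulfanyl brings 2 heavy atoms in place of the single bromine and adds 1 hydrogen-bond acceptor where bromo has none, yet a 1.2-fold higher number from compound 1 to compound 4 (0.08 log units; within the scatter) in this assay, which means compound 1 and compound 4 cannot be told apart on these numbers. The compounds shown give no measured property or other information that would account for this result.

Going by these compounds, what remains open is whether any group at this position can move the number beyond the scatter, since so far bromo and methylsulfanyl are the only two seen there. An amine, a carboxylic acid or a longer chain on that carbon would test this, and only such a result would show whether this position matters in this assay or whether the number depends on other parts of the shared core.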